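Replacing One Aromatic Group on a Shared Core

The source may hold more compounds than are shown below. What is called first, only, known or untested is meant among the compounds shown, and "the series" means these compounds.

Compound 1 `Nc1ccc(S(=O)(=O)N2CCN(c3ncc(C(O)(C(F)(F)F)C(F)(F)F)cc3C#CC3CC3)CC2)cn1` gives 67 mL.min-1.g-1
Compound 2 `Nc1ccc(S(=O)(=O)N2CCN(c3ncc(C(O)(C(F)(F)F)C(F)(F)F)cc3-c3ccccc3O)CC2)cn1` gives 125 mL.min-1.g-1
Compound 3 `CS(=O)(=O)Nc1cccc(-c2cc(C(O)(C(F)(F)F)C(F)(F)F)cnc2N2CCN(S(=O)(=O)c3ccc(N)nc3)CC2)c1` gives 81 mL.min-1.g-1

These three numbers come from an ADME assay (liver) for metabolic stability, with Liver microsome (Rattus norvegicus) as the target, using microsomes and NADPH, with a stated time of 30 min, tested at 1 uM (a lower number here means slower removal, a higher number faster removal of the compound), and they differ only by the group on one aromatic carbon of the shared core. Compound 3 stands within the scatter of both other compounds, so the three values cannot be ranked.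

The next compound is compound 4 `Nc1ccc(S(=O)(=O)N2CCN(c3ncc(C(O)(C(F)(F)F)C(F)(F)F)cc3-c3cccnc3)CC2)cn1` which carries pyridin-3-yl in place of 3-(methanesulfonamido)phenyl on an aromatic carbon of a six-membered aromatic ring with 1 nitrogen. Going by the values given here, the change is counted as follows: pyridin-3-yl in place of 3-(methanesulfonamido)phenyl on an aromatic carbon and it removes the only sulfonamide-bearing group in this small set.

Three measured exchanges at the same place bear on this one. They are a 1.2-fold higher number from compound 1 to compound 3 (0.08 log units; within the scatter) and a 1.5-fold lower number from compound 2 to compound 3 (0.19 log units; within the scatter) and a 1.9-fold higher number from compound 1 to compound 2 (0.27 log units; within the scatter) and none of them goes beyond the scatter. None of them involves pyridin-3-yl, so they give only indirect guidance, and no step beyond the scatter is expected in this assay on this evidence.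

The expected change is a 1.0-fold higher number from compound 3 to compound 4 (0.02 log units; within the scatter) and this is no real shift. For compound 4 the estimated value is 85 mL.min-1.g-1 with an expected range from 45 mL.min-1.g-1 to 160 mL.min-1.g-1 when it is measured.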

Compound 4, intrinsic clearance in microsomes: 20 mL.min-1.g-1
Beside the measured number, compound 4's estimate is 4.3-fold (0.63 log units) above it, outside the stated range (below it).
By their numbers in this assay, from the lowest: compound 4; then compounds 1, 3 and 2 (each within the scatter of the next).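

In this assay, the three earlier groups on this aromatic carbon, ortho to a large group, stayed within the scatter of one another, so they gave no sign that the position could move the number. Pyridin-3-yl does move it, with a 4.1-fold lower number from compound 3 to compound 4 (0.61 log units; beyond the scatter) and a 6.3-fold lower number from compound 2 to compound 4 (0.80 log units; beyond the scatter) and a 3.4-fold lower number from compound 1 to compound 4 (0.53 log units; beyond the scatter) as its three steps, each beyond the scatter and each towards slower removal. The step from compound 3 exchanges a group of 11 heavy atoms and 1 hydrogen-bond donor for one of 6 heavy atoms and 0 donors, but nothing shown here gives a cause for the lower number.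

As far as these compounds go, it remains open whether the lower number depends on the nitrogen of the entering ring, which an unsubstituted phenyl group at this place would test, or on where that nitrogen sits, which pyridin-4-yl would test. From the compounds shown here alone, it is also open whether the number stays low when a methyl group or an amine is carried on the pyridin-3-yl ring.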